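Aryl swap at the imine carbon: working notes

The source may hold more compounds than are shown below. What is called first, only, known or untested is meant among the compounds shown, and "the series" means these compounds.

compound 1: `CN(C)CCn1cnnc1-c1cc(Oc2ccc(NC(=O)N/N=C/c3c[nH]c4ccccc34)cc2F)ccn1`; in a functional assay on HT-29 cells (Homo sapiens) for cytotoxicity, read by MTT assay, with a stated time of 72 h (on this read-out lower numbers stand for stronger inhibition and higher numbers for weaker inhibition), compound 1 gives 1300 nM
compound 2: `COc1ccc(/C=N/NC(=O)Nc2ccc(Oc3ccnc(-c4nncn4CCN(C)C)c3)c(F)c2)c(OC)c1OC`; in this assay compound 2 gives 3970 nM

Compound 2 stands as the highest of the two numbers in this assay; the nearest is compound 1, reached through a 3.1-fold higher number from compound 1 to compound 2 (0.48 log units; beyond the scatter). Going by the values given here, that is the only measured step, and it touches the same position as the change now in question.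

Compound 3 is `CN(C)CCn1cnnc1-c1cc(Oc2ccc(NC(=O)N/N=C/c3ccccc3O[N+](=O)[O-])cc2F)ccn1`. It carries 2-(nitrooxy)phenyl in place of 2,3,4-trimethoxyphenyl on a carbon with a double bond to nitrogen. Among the compounds with values here, no measured step involves the entering group, so the size of the effect cannot be read from the series. Within the data shown here, the one step at this position, a 3.1-fold higher number from compound 1 to compound 2 (0.48 log units; beyond the scatter), shows that the group on this carbon can shift the number beyond the scatter, and that is taken as the only guide to the width of the range; no direction is claimed.

Compound 3 is expected at 2500 nM, with a range from 800 nM to 8000 nM. This estimate amounts to a 1.6-fold lower number from compound 2 to compound 3 (0.20 log units; within the scatter).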

Compound 3, half-maximal inhibitory concentration: 950 nM
Estimate against measurement, compound 3: 2.6-fold (0.42 log units) above; the range from low to high includes it.
By their numbers in this assay, from the lowest: compounds 3 and 1 (each within the scatter of the next); then compound 2.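

In this assay, replacing 2,3,4-trimethoxyphenyl with 2-(nitrooxy)phenyl on the carbon with a double bond to nitrogen gives a 4.2-fold lower number from compound 2 to compound 3 (0.62 log units; beyond the scatter) and so shows that a second group can move the number beyond the scatter at this position. The comparison with 1H-indol-3-yl gives a 1.4-fold lower number from compound 1 to compound 3 (0.14 log units; within the scatter) and places 2-(nitrooxy)phenyl level with that group, leaving compound 2 as the only one of the three set apart. No supporting data bear on what lies behind these differences.

The compounds shown leave open whether the nitrooxy group or the phenyl ring accounts for the number of compound 3; an unsubstituted phenyl or a 2-hydroxyphenyl on this carbon would separate the two. Also open, going by these compounds, is whether the same grouping of the three compounds holds in another cell line.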